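Chlorine position on the aromatic nitrogen aryl group

A few compounds are considered here, and "the series" means these few. Any claim that something is new, unique, unknown or untested is made for them only; others in the source may bear on it.

Among the measured compounds shown here, compound 2 `O=c1[nH]cc(S(=O)(=O)Nc2ccccc2-c2cn(-c3ccccc3Cl)nn2)c(=O)[nH]1` gives 6520 nM in a functional assay on SGC-7901 cells (Homo sapiens) for antiproliferative activity, read by MTT assay, with a stated time of 24 h (a lower number here means a stronger inhibitor, a higher number a weaker inhibitor), and is the only compound of the pair with a number rather than a limit. Compound 1 `O=c1[nH]cc(S(=O)(=O)Nc2ccccc2-c2cn(-c3ccc(F)cc3)nn2)c(=O)[nH]1` reaches only the assay limit, > 20000 nM (the limit of > 20000 nM in this assay, at which 1 of the 2 values shown sits). For the measured compounds named here, the one measured step, an at least 3.0-fold lower number from compound 1 to compound 2 (0.48 log units; beyond the scatter), changes the halogen and its position at once, so a change of position alone has no measured precedent here. Compound 3 `O=c1[nH]cc(S(=O)(=O)Nc2ccccc2-c2cn(-c3cccc(Cl)c3)nn2)c(=O)[nH]1` differs from compound 2 by 3-chlorophenyl in place of 2-chlorophenyl on an aromatic nitrogen. No step beyond the scatter is therefore expected in this assay, with wide uncertainty. Compound 3 is estimated at 7000 nM (2500 nM to 20000 nM), the expected step being a 1.1-fold higher number from compound 2 to compound 3 (0.03 log units; within the scatter).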

Compound 3, half-maximal inhibitory concentration: 2270 nM
Beside the measured number, compound 3's estimate is 3.1-fold (0.49 log units) above it; measured number below the stated range.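

In this assay, the position of the chlorine alone now has a measured effect: 3-chlorophenyl in place of 2-chlorophenyl gives a 2.9-fold lower number from compound 2 to compound 3 (0.46 log units; beyond the scatter). Putting 3-chlorophenyl in place of 4-fluorophenyl gives an at least 8.8-fold lower number from compound 1 to compound 3 (0.94 log units; beyond the scatter), with halogen and position changed at once. That step starts from a limit held by compound 1, not from a number: the limit of > 20000 nM in this assay, at which 1 of the 3 values shown sits.

Still open, on these data alone, is how 4-chlorophenyl would compare, which would separate halogen from position. Also open, as far as these compounds go, is whether 3-methoxyphenyl or 3-aminophenyl on this aromatic nitrogen would match 3-chlorophenyl.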